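The compounds below may be only part of what the source reports. "The series", "measured", "known", "first", "only" and "open" are said of these compounds alone.

In a functional assay on the whole organism (plasma, strain Wistar) with Rattus norvegicus as the target, with a stated time of 15 days, at a dose of 3 mg/kg by the oral route (a higher number here means a stronger effect of the compound at the dose given, a lower number a weaker effect), compound 1 `COc1ccc(-c2nnc(SCCOc3ccc(/C=C4\SC(=O)NC4=O)cc3)[nH]2)cc1` gives 41.3%. Compound 2 `O=C1NC(=O)/C(=C/c2ccc(OCCSc3nnc(-c4ccccc4)o3)cc2)S1` gives 11.6% in this assay, and compound 3 `O=C1NC(=O)/C(=C/c2ccc(OCCSc3nnc(Cc4ccccc4)o3)cc2)S1` gives 14.2% in this assay. On these three numbers compound 3 stands second highest, nearest to compound 2 and furthest from compound 1. Going by the values given here, the only measured step is a number 2.6 percentage points higher from compound 2 to compound 3 (within the scatter). Compound 4 `O=C1NC(=O)/C(=C/c2ccc(OCCSc3nnc(-c4cccnc4)o3)cc2)S1` differs from compound 3 by pyridin-3-yl in place of benzyl on an aromatic carbon. Among the compounds with values here, no measured step bears directly on this change: the step from phenyl to benzyl stayed within the scatter, and no compound in the set carries a pyridin-3-yl group. For compound 4 the step of a number 1.8 percentage points higher from compound 3 to compound 4 (within the scatter) is therefore expected to stay within the scatter. Compound 4 is estimated to give 16% in this assay, with a range from 4% to 34%.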

Compound 4, a percentage reported as activity, at one dose (the size of the read-out at that dose, not a potency): 24.4%
Compound 4: middle estimate off by 8.4 percentage points, on the low side, and the stated range covers the measured number.
By their numbers in this assay, from the lowest: compounds 2 and 3 (each within the scatter of the next); then compound 4; then compound 1.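

In this assay, pyridin-3-yl in place of benzyl gives a number 10.2 percentage points higher from compound 3 to compound 4 (beyond the scatter), and pyridin-3-yl in place of phenyl gives a number 12.8 percentage points higher from compound 2 to compound 4 (beyond the scatter). This position on the five-membered ring, where phenyl and benzyl stayed within the scatter of each other, therefore does respond to a change of group, here one that brings a ring nitrogen and a hydrogen-bond acceptor. Nothing available explains this rise. The compounds shown leave open whether the place of the ring nitrogen matters, as pyridin-2-yl or pyridin-4-yl would tell. They also leave open how an amine or a carboxylic acid on the phenyl ring would compare.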